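The compounds below may be only part of what the source reports. "The series", "measured", "known", "first", "only" and "open" are said of these compounds alone.

Measured in a functional assay on HCT-116 cells (Homo sapiens) for cytotoxicity, read by MTT assay, with a stated time of 72 h; a higher number here means a weaker inhibitor, a lower number a stronger inhibitor:
compound 1 `COc1ncc(-c2ccc3nc(NC(=O)NCC(=O)N4CCCCC4)nn3c2)cc1NS(=O)(=O)c1ccc(F)cc1`: 130 nM
compound 2 `COc1ncc(-c2ccc3nc(NC(=O)N4CCCC4)nn3c2)cc1NS(=O)(=O)c1ccc(F)cc1`: 1290 nM
compound 3 `COc1ncc(-c2ccc3nc(NC(=O)NCC(=O)N4CCCC4)nn3c2)cc1NS(=O)(=O)c1ccc(F)cc1`: 140 nM

Compound 3 sits level with compound 1 and well under compound 2. Exchanging the terminal ring alone left the number unmoved: a 1.1-fold higher number from compound 1 to compound 3 (0.03 log units; within the scatter). Compound 4 `CCCNC(=O)Nc1nc2ccc(-c3cnc(OC)c(NS(=O)(=O)c4ccc(F)cc4)c3)cn2n1` is next: ethyl in place of (pyrrolidin-1-yl)carbonyl on a saturated chain carbon bound to an amide-type nitrogen. Propyl thus replaces ((pyrrolidin-1-yl)carbonyl)methyl. For the measured compounds named here, the nearest precedent is a 9.2-fold lower number from compound 2 to compound 3 (0.96 log units; beyond the scatter), where (((pyrrolidin-1-yl)carbonyl)methyl)amino entered in place of pyrrolidin-1-yl. Its counterpart is a 9.9-fold higher number from compound 1 to compound 2 (1.00 log units; beyond the scatter). Compound 4 also loses the (pyrrolidin-1-yl)carbonyl, but keeps a chain, so a partial reversal of those modest steps is expected. The expected move is a 2.5-fold higher number from compound 3 to compound 4 (0.40 log units; beyond the scatter). For compound 4 the estimate is 350 nM (expected range 110 nM to 1100 nM).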

Compound 4, half-maximal inhibitory concentration: 150 nM
The estimate for compound 4 lay 2.3-fold (0.37 log units) above the measured number, and the stated range covers the measured number.
By their numbers in this assay, from the lowest: compounds 1, 3 and 4 (each within the scatter of the next); then compound 2.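

In this assay, the (pyrrolidin-1-yl)carbonyl is dispensable at this place: ethyl replaces it with a 1.1-fold higher number from compound 3 to compound 4 (0.03 log units; within the scatter), and replacing the (piperidin-1-yl)carbonyl gives a 1.2-fold higher number from compound 1 to compound 4 (0.06 log units; within the scatter). The large gap to the pyrrolidin-1-yl on the carbonyl carbon therefore survives with a plain propylamino, at an 8.6-fold lower number from compound 2 to compound 4 (0.93 log units; beyond the scatter), so neither the second carbonyl nor the terminal ring is required to keep it. No measurement on these compounds bears on why this is so. Open, on these data alone, is how far the chain tolerates change: a methyl, a longer chain such as butyl, or a propyl ending in an amine or a carboxylic acid.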